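The compounds below may be only part of what the source reports. "The series", "measured", "known", "first", "only" and "open" are said of these compounds alone.

Working notes on the series. Within the data shown here, in a functional assay on NCI-H460 cells (Homo sapiens) for inhibition, read by sulforhodamine B assay, with a stated time of 72 h (a lower number here means a stronger inhibitor, a higher number a weaker inhibitor), compound 1 (`CCOC(=O)c1noc2c1CN(C(=O)c1cc(C(C)C)c(O)cc1O)CC2`) gives 870 nM and compound 2 (`CCNC(=O)c1noc2c1CN(C(=O)c1cc(C(C)C)c(O)cc1O)CC2`) gives 450 nM as the only two values so far, so compound 2 stands within the scatter of its single neighbour. Compound 3 (`CC(C)c1cc(C(=O)N2CCc3onc(C(=O)NC4CCCC4)c3C2)c(O)cc1O`) has cyclopentyl in place of ethyl on an amide-type nitrogen. Among the measured compounds shown here, the one measured step (a 1.9-fold lower number from compound 1 to compound 2 (0.29 log units; within the scatter)) is ethylamino in place of ethoxy on a carbonyl carbon. For the measured compounds named here, that step does not vary the group on the nitrogen, so no measured step tests this change directly and the series gives no direction for it. In this assay no shift beyond the scatter is therefore expected, and the estimated step (a 1.1-fold higher number from compound 2 to compound 3 (0.05 log units; within the scatter)) carries a wide range. For compound 3 the expected value is 500 nM with 170 nM to 1500 nM as the estimated range.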

Compound 3, half-maximal inhibitory concentration: 900 nM
Estimate against measurement, compound 3: 1.8-fold (0.26 log units) below, within the range that was stated.
By their numbers in this assay, from the lowest: compounds 2, 1 and 3 (each within the scatter of the next).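

In this assay the amide-type nitrogen carries cyclopentyl in place of ethyl with the step still inside the scatter (a 2.0-fold higher number from compound 2 to compound 3 (0.30 log units; within the scatter)). Among these compounds, this is the first variation of the group on that nitrogen, and it shows that a five-membered carbon ring can stand there without a shift beyond the scatter; the other new step likewise gives no such shift (a 1.0-fold higher number from compound 1 to compound 3 (0.01 log units; within the scatter)). No measurement bears on why these numbers stand where they do.

Going by these compounds, whether a phenyl ring, a hydroxyethyl chain or a longer chain such as hexyl on this nitrogen would move the number beyond the scatter remains open. Among the compounds shown here, no step at this position yet reads as a real change, so no trend with the size of the group can be drawn.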